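This account rests on a few compounds, and the source may have more. Where it says the series, first, only, none or still open, it means among the compounds named here.

Measured compounds:
Compound 1 `COc1ccc(/C=N/NC(=S)NC(C)(C)[C@H]2CC=C(C)CC2)cc1`: in a functional assay on U-251 cells (Homo sapiens) for inhibition, read by sulforhodamine B assay, with a stated time of 48 h (on this read-out lower numbers stand for stronger inhibition of growth and higher numbers for weaker inhibition of growth), compound 1 gives 71900 nM.
Compound 2 `CC1=CC[C@H](C(C)(C)NC(=S)N/N=C/c2ccc(N(C)C)cc2)CC1`: in this assay compound 2 gives only a limit of the assay, > 100000 nM.

Among the measured compounds shown here, compound 1 thus holds the only number in this assay; the other value is a limit, as the limit of > 100000 nM in this assay, at which 1 of the 2 values shown sits, records. For the measured compounds named here, the single measured step, an at least 1.3-fold higher number from compound 1 to compound 2 (0.14 log units; that floor lies within the scatter), concerns dimethylamino in place of methoxy on an aromatic carbon and ends at a limit rather than a number.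

Compound 3 `CC1=CC[C@H](C(C)(C)NC(=S)N/N=C/c2cccs2)CC1` is not yet measured in this assay. Its change from compound 1 is thiophen-2-yl in place of 4-methoxyphenyl on a carbon with a double bond to nitrogen. Going by the values given here, no measured step covers this exchange of the whole aromatic group on the carbon with a double bond to nitrogen; the step from compound 1 to compound 2 only varies a substituent on the 4-methoxyphenyl and gives no guide here. Without a bearing step, the expectation for compound 3 in this assay is a step no larger than the scatter, with a wide range and a real chance that only a limit is returned. Compound 3 is estimated at 70000 nM, between 30000 nM and 100000 nM. The step this estimate implies, a 1.0-fold lower number from compound 1 to compound 3 (0.01 log units; within the scatter), is expected to stay within the scatter.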

Compound 3, concentration for total growth inhibition: 27400 nM
Estimate against measurement, compound 3: 2.6-fold (0.41 log units) above, outside the stated range (below it).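

In this assay thiophen-2-yl in place of 4-methoxyphenyl on a carbon with a double bond to nitrogen gives a 2.6-fold lower number from compound 1 to compound 3 (0.42 log units; beyond the scatter) so this position responds to exchange of the whole aromatic group, not only to a substituent change on the 4-methoxyphenyl. Compound 2 gives > 100000 nM which is a limit and not a number, so the step to compound 3 is the only one in this small set that joins two numbers. The exchange replaces a six-membered aromatic ring of carbon only with a five-membered aromatic ring with 1 hetero atom, and it also leaves fewer heavy atoms on this carbon, but no measurement shown bears on the cause of the step.

Ring size and the sulfur atom change together here, so the compounds shown do not separate their contributions; an unsubstituted phenyl or a furan-2-yl on the same carbon would bear on that question. Also open, as far as these compounds go, is whether the step carries over to other parts of the shared core, such as a replacement of the two methyl groups on the carbon bonded to the thiourea nitrogen by a longer chain or a ring.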